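Swapping a fused bicyclic amine for a dimethylaminopyrrolidine

A few compounds are considered here, and "the series" means these few. Any claim that something is new, unique, unknown or untested is made for them only; others in the source may bear on it.

Measured so far:
compound 1, `CN1CC[C@H]2CN(c3cccc4c3C[C@H](CN(C)[C@H]3CCCc5cccnc53)NC4)C[C@H]21`: 87.3%
compound 2, `CN1C[C@@H]2CN(c3cccc4c3C[C@H](CN(C)[C@H]3CCCc5cccnc53)NC4)C[C@@H]2C1`: 100%
compound 3, `CN(C)[C@@H]1CCN(c2cccc3c2C[C@H](CN(C)[C@H]2CCCc4cccnc42)NC3)C1`: "not determined" (no result reported)

In an ADME assay on microsomes from liver (Homo sapiens) for metabolic stability, using NADPH, with a stated time of 10 min (a lower number here means that less of the compound is left, a higher number that more of the compound is left), compound 1 gives 87.3%, the lower of the two numbers available, and compound 2 gives 100%. Going by the values given here, the only measured step, a number 12.7 percentage points higher from compound 1 to compound 2 (beyond the scatter), exchanges one pair of fused five-membered rings for another on the aromatic carbon of the shared core.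

Compound 4, `CN(C)[C@H]1CCN(c2cccc3c2C[C@H](CN(C)[C@H]2CCCc4cccnc42)NC3)C1`, is made from compound 1 by a different exchange: a group of 8 heavy atoms (6 carbon, 2 nitrogen; one five-membered non-aromatic ring with 1 hetero atom) in place of a group of 9 heavy atoms (7 carbon, 2 nitrogen; 2 five-membered non-aromatic rings with 1 hetero atom each), on an aromatic carbon. Among the compounds with values here, no measured step covers this particular replacement; compound 3 carries the same kind of group but gives "not determined" (no result reported). Within the data shown here, the one step available shows that reshaping the amine at this position moved the read-out only modestly, so a change of similar or smaller size, in either direction, is expected here. Compound 4 is therefore estimated at 85%, in the range 65% to 100%, which means a step of a number 2.3 percentage points lower from compound 1 to compound 4 (within the scatter) is expected.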

Compound 4, percent of the compound remaining: 67.5%
Beside the measured number, compound 4's estimate is 17.5 percentage points above it, and the stated range covers the measured number.
By their numbers in this assay, from the lowest: compound 4; then compound 1; then compound 2.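

Going by these compounds alone, until now this aromatic carbon had only carried fused bicyclic amines, and the one step between them was modest. Moving to the single-ring 3-(dimethylamino)pyrrolidin-1-yl group in this assay gives a number 19.8 percentage points lower from compound 1 to compound 4 (beyond the scatter), and measured against the other fused amine it gives a number 32.5 percentage points lower from compound 2 to compound 4 (beyond the scatter). Both steps lie beyond the scatter, so the choice of amine at this position can change how much compound is left by more than the earlier pair showed, and less of compound 4 remains than of either fused amine.

From the compounds shown here alone, compound 3 has no number, so what the configuration of the pyrrolidine contributes stays open: the fact that compounds 3 and 4 differ only in the configuration as drawn Also open is whether another single-ring amine, such as a piperazine or a morpholine, would sit nearer compound 4 or the fused amines.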